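This account rests on a few compounds, and the source may have more. Where it says the series, first, only, none or still open, it means among the compounds named here.

Measured so far:
Compound 1, `CC1=Cc2c(cc(C)oc2=O)OC1C` — in a functional assay on SH-SY5Y cells (Homo sapiens) for antiproliferative activity, with a stated time of 24 h, tested at 12.5 ug/mL (on this read-out lower numbers stand for a weaker effect and higher numbers for a stronger effect at the one concentration tested), compound 1 gives "not determined" (no result reported).
Compound 2, `CCC1C=Cc2c(cc(C)oc2=O)O1` — in this assay compound 2 gives 3.62%.

Within the data shown here, compound 1 therefore stands nowhere on the numbers: it has no result of its own, and the only number belongs to compound 2. Compound 3, `CC1=Cc2c(cc(C)oc2=O)OC1c1ccco1`, differs from compound 1 by furan-2-yl in place of methyl on a saturated ring carbon. Among the measured compounds shown here, no step between two measured compounds is known, so the data give no direction for this change; the expected step in this assay is none beyond the scatter, in either direction. For compound 3 the inhibition is estimated at 8%, expected to fall between 0% and 25%.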

Compound 3, a percentage reported as inhibition, at one concentration (the size of the read-out at that concentration, not a potency): 50.7%
Compound 3: the middle estimate sits 42.7 percentage points below what was measured; the whole stated range lies below it.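

Among these compounds, no step from compound 1 to compound 3 can be read: in this assay compound 1 gives "not determined" (no result reported) while compound 3 gives 50.7% with no number to set it against. Going by these compounds, what furan-2-yl in place of methyl does to the inhibition stays open, and no evidence on hand bears on this result.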